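The source may hold more compounds than are shown below. What is called first, only, known or untested is meant among the compounds shown, and "the series" means these compounds.

Compound 1 `c1ccc(NN=C(c2nc3ccccc3[nH]2)c2nc3ccccc3[nH]2)cc1`: 3800 nM
Compound 2 `Clc1ccc(NN=C(c2nc3ccccc3[nH]2)c2nc3ccccc3[nH]2)cc1`: 2800 nM

In a functional assay on A549 cells (Homo sapiens) for cytotoxicity, read by MTT assay, with a stated time of 72 h (on this read-out higher numbers stand for weaker inhibition and lower numbers for stronger inhibition), compound 2 stands at one end of the two numbers, with compound 1 the nearest and the step of a 1.4-fold lower number from compound 1 to compound 2 (0.13 log units; within the scatter) within the scatter. Compound 3 `O=[N+]([O-])c1ccc(NN=C(c2nc3ccccc3[nH]2)c2nc3ccccc3[nH]2)cc1` differs from compound 2 by nitro in place of chloro on an aromatic carbon. Among the compounds with values here, the only measured step that bears on this position is a 1.4-fold lower number from compound 1 to compound 2 (0.13 log units; within the scatter), which was within the scatter; no measured compound carries a nitro group, so no direction is supported by the data. No step beyond the scatter is expected, a 1.1-fold lower number from compound 2 to compound 3 (0.05 log units; within the scatter). For compound 3 the estimate in this assay is 2500 nM, range 800 nM to 8000 nM.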

Compound 3, half-maximal inhibitory concentration: 700 nM
Beside the measured number, compound 3's estimate is 3.6-fold (0.55 log units) above it; measured number below the stated range.
By their numbers in this assay, from the lowest: compound 3; then compounds 2 and 1 (each within the scatter of the next).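

Nitro at this place, on the carbon-only aromatic ring para to a large group, gives the first step beyond the scatter in this assay: a 4.0-fold lower number from compound 2 to compound 3 (0.60 log units; beyond the scatter) and a 5.4-fold lower number from compound 1 to compound 3 (0.73 log units; beyond the scatter). The position therefore responds to substitution, and the response depends on the group, as chloro alone gave no step beyond the scatter. No evidence on hand bears on the reason for this gain.

Still open, going by these compounds, is whether an amine, a carboxylic acid or a methoxy group at this place would follow nitro or chloro. Also open, on these data alone, is whether nitro elsewhere on the ring would give a similar step.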